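A few compounds are considered here, and "the series" means these few. Any claim that something is new, unique, unknown or untested is made for them only; others in the source may bear on it.

In a functional assay on MCF7 cells (Homo sapiens) for inhibition, read by MTT assay, with a stated time of 48 h (on this read-out lower numbers stand for stronger inhibition and higher numbers for weaker inhibition), compound 1 (`Fc1ccccc1CSc1nnc(-c2ccncc2)n1-c1ccccc1`) returns only a limit (> 50000 nM), not a number. Compound 2 (`Clc1ccccc1CSc1nnc(-c2ccncc2)n1-c1ccccc1`) gives 18100 nM in the same read-out, and compound 3 (`Fc1ccc(CSc2nnc(-c3ccncc3)n2-c2ccccc2)cc1`) gives 21100 nM there. For the measured compounds named here, these are the only two numbers so far, and they stand level (a 1.2-fold higher number from compound 2 to compound 3 (0.07 log units; within the scatter)), so compound 2 shares its place with compound 3.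

The step under consideration leads from compound 2 to compound 4 (`Fc1cccc(F)c1CSc1nnc(-c2ccncc2)n1-c1ccccc1`), with 2,6-difluorophenyl in place of 2-chlorophenyl on a saturated chain carbon bound to a sulfur.

Going by the values given here, two measured steps bear on this change, both starting from the limit of compound 1. Chloro in place of fluoro gave an at least 2.7-fold lower number from compound 1 to compound 2 (0.44 log units; beyond the scatter) as its result, and 4-fluorophenyl in place of 2-fluorophenyl gave an at least 2.3-fold lower number from compound 1 to compound 3 (0.37 log units; beyond the scatter) as its result. Compound 4 has fluoro again where compound 2 has chloro, so a modest step towards a higher number is expected in this assay, on the evidence of compound 1 (an at least 2.7-fold lower number from compound 1 to compound 2 (0.44 log units; beyond the scatter)). The expected move is an estimated one (a 1.7-fold higher number from compound 2 to compound 4 (0.22 log units; within the scatter)). A result reported only as a limit also remains possible, given the limit of > 50000 nM in this assay, at which 1 of the 3 values shown sits, as the ceiling. For compound 4 the expected value is 30000 nM within an estimated range from 13000 nM to 70000 nM in this read-out.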

Compound 4, half-maximal inhibitory concentration: > 50000 nM
Compound 4: a limit, no number (the forecaster's own chance of this, stated with the estimate: 35%); middle value at least 1.6-fold (0.22 log units) from the limit.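

In this assay, 2,6-difluorophenyl in place of 2-chlorophenyl on the saturated chain carbon bound to the sulfur gives an at least 2.7-fold higher number from compound 2 to compound 4 (0.44 log units; beyond the scatter), and in place of 4-fluorophenyl it gives an at least 2.3-fold higher number from compound 3 to compound 4 (0.37 log units; beyond the scatter). Compound 4 returns a limit and not a number, which puts a second compound at the ceiling of the read-out: the limit of > 50000 nM in this assay, at which 2 of the 4 values shown sit. Among the four groups shown, 2-chlorophenyl and 4-fluorophenyl give numbers while 2-fluorophenyl and 2,6-difluorophenyl give limits, so the added fluoro does not bring compound 4 back into the measurable range, and the step from compound 1 to compound 4 cannot be read, both ends being limits.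

As far as these compounds go, how far compound 1 and compound 4 lie past the limit stays unknown, and so does any order between them. Also open, from the compounds shown here alone, is whether a 2,6-dichlorophenyl group, or a benzyl group carrying an amine or a carboxylic acid, would return a number in this assay.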